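Cyclopentyl to cyclohexyl on an aromatic nitrogen

The compounds below may be only part of what the source reports. "The series", "measured", "known", "first", "only" and "open" are said of these compounds alone.

Measured in a functional assay on DU-145 cells (Homo sapiens) for inhibition, read by trypan blue exclusion, with a stated time of 72 h; a higher number here means a weaker inhibitor, a lower number a stronger inhibitor:
- compound 1 `O=c1c(S(=O)(=O)c2ccc(F)cc2F)cc2cnc(Nc3ccc4[nH]ccc4c3)nc2n1C1CCCC1`: 5000 nM
- compound 2 `Cn1c(=O)c(S(=O)(=O)c2ccc(O)cc2)cc2cnc(Nc3ccc4[nH]ccc4c3)nc21`: 250 nM
- compound 3 `Cn1c(=O)c(S(=O)(=O)Nc2ccc(F)cc2)cc2cnc(Nc3ccc4[nH]ccc4c3)nc21`: 5000 nM

Compound 1, at 5000 nM, stands level with compound 3 at the weak end of these numbers, while compound 2 has the clearly lower value. Compound 4 `O=c1c(S(=O)(=O)c2ccc(F)cc2F)cc2cnc(Nc3ccc4[nH]ccc4c3)nc2n1C1CCCCC1` keeps the core of compound 1 but carries cyclohexyl in place of cyclopentyl on an aromatic nitrogen.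

Within the data shown here, the only measured step is large: a 20-fold higher number from compound 2 to compound 3 (1.30 log units; beyond the scatter). However, it concerns a group on a sulfonyl sulfur, not the aromatic nitrogen, so it offers little guidance here. Among the measured compounds shown here, no measured pair shows what swapping cyclopentyl for cyclohexyl does. With no evidence for a shift in either direction, no step beyond the scatter is expected in this assay, and the estimate stays anchored on compound 1 at 5000 nM. The expected step is no change at the digits printed from compound 1 to compound 4 (within the scatter). Compound 4 is estimated at 5000 nM, with an expected range from 2000 nM to 12000 nM.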

Compound 4, half-maximal inhibitory concentration: 10000 nM
Estimate against measurement, compound 4: 2.0-fold (0.30 log units) below; measured number inside the range.
By their numbers in this assay, from the lowest: compound 2; then compounds 1, 3 and 4 (each within the scatter of the next).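

On the aromatic nitrogen of the core of compound 1, cyclohexyl in place of cyclopentyl gives, in this assay, a 2.0-fold higher number from compound 1 to compound 4 (0.30 log units; within the scatter). Among these compounds, this is the first direct reading of this position, since the only earlier step concerned a group on a sulfonyl sulfur. With the (2,4-difluorophenyl)sulfonyl group held fixed, this assay does not tell the five-membered ring from the six-membered ring, and nothing shown explains this result.

On these data alone, both groups are rings of carbon only, so it remains open how this position would respond to a ring carrying nitrogen or oxygen, such as piperidine or morpholine, or to an open chain such as butyl. Methyl on this nitrogen also remains open, as it appears only in compound 2 and compound 3, each with a different group on the sulfonyl sulfur.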